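The source may hold more compounds than are shown below. What is called first, only, known or untested is meant among the compounds shown, and "the series" means these compounds.

Measured so far in a functional assay on A549 cells (Homo sapiens) for antiproliferative activity, read by MTT assay, with a stated time of 72 h; a lower number here means a stronger inhibitor, a higher number a weaker inhibitor:
compound 1 `Cc1ccc(-c2noc(CCCCCCC(=O)NO)n2)cc1` gives 5810 nM
compound 2 `O=C(CCCCCCc1nc(-c2ccc(C(F)(F)F)cc2)no1)NO` gives 14000 nM
compound 3 `O=C(CCCCCCc1nc(-c2ccc(F)cc2)no1)NO` gives 5770 nM

Compound 3, with fluoro on its aromatic ring, cannot be told apart from the methyl member of the set (a 1.0-fold lower number from compound 1 to compound 3 (0.00 log units; within the scatter)). The trifluoromethyl member stands apart from it by a modest but real margin (a 2.4-fold lower number from compound 2 to compound 3 (0.38 log units; beyond the scatter)). Compound 3 therefore belongs to the better pair of this small group, without leading it.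

In compound 4 `O=C(CCCCCCc1nc(-c2ccccc2Cl)no1)NO`, 2-chlorophenyl stands in place of 4-fluorophenyl 2-chlorophenyl in place of 4-fluorophenyl on an aromatic carbon on an aromatic carbon. The whole group changes here, while the rest of the molecule stays the same. The measured steps that bear on this change are the swaps on that same aromatic ring. So far these have been either modest (a 2.4-fold higher number from compound 1 to compound 2 (0.38 log units; beyond the scatter)) or lost in the scatter (a 1.0-fold lower number from compound 1 to compound 3 (0.00 log units; within the scatter)). For the measured compounds named here, none of the measured compounds carries 2-chlorophenyl, so these steps guide the size of the change only loosely and say little about its direction.

A small step is therefore expected in this assay, most likely no larger than those already seen, with a slight lean towards a higher number. The expected change is a 1.2-fold higher number from compound 3 to compound 4 (0.08 log units; within the scatter) and remains an estimate. For compound 4 the estimated value is 7000 nM with an expected range from 3000 nM to 16000 nM.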

Compound 4, half-maximal inhibitory concentration: 8870 nM
The estimate for compound 4 lay 1.3-fold (0.10 log units) below the measured number; the measured number falls inside the stated range.
By their numbers in this assay, from the lowest: compounds 3, 1, 4 and 2 (each within the scatter of the next, the first and the last beyond it).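

Compound 4 changes both the atom on the phenyl ring and where that atom sits, yet in this assay the result cannot be told apart from either neighbouring compound (a 1.5-fold higher number from compound 3 to compound 4 (0.19 log units; within the scatter); a 1.5-fold higher number from compound 1 to compound 4 (0.18 log units; within the scatter)). This position on the five-membered ring therefore accepts 2-chlorophenyl in place of 4-fluorophenyl or 4-methylphenyl without a step that rises above the noise of the measurement. Among the steps at this position, those to and from the trifluoromethyl compound remain the only ones beyond the scatter (a 2.4-fold higher number from compound 1 to compound 2 (0.38 log units; beyond the scatter); a 2.4-fold lower number from compound 2 to compound 3 (0.38 log units; beyond the scatter)), so moving the substituent on the ring has shown no clear effect here, and nothing measured offers an explanation for these small differences.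

On these data alone, with so few compounds, all of them phenyl groups bearing a single methyl, trifluoromethyl, fluoro or chloro substituent, it remains open how this assay would respond to a phenyl ring carrying an amine or a carboxylic acid. A pyridine ring in place of the phenyl ring, or a shorter or longer chain leading to the hydroxamic acid, is equally untested by the compounds shown.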